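This account rests on a few compounds, and the source may have more. Where it says the series, first, only, none or still open, it means among the compounds named here.

Working notes, series tested in a functional assay on PC-3 cells (Homo sapiens) for cytotoxicity, read by WST assay, with a stated time of 72 h; on this read-out lower numbers stand for stronger inhibition and higher numbers for weaker inhibition; each value below is a limit, not a number.

- compound 1 `O=C1Nc2c(ccc(F)c2F)C1(c1ccc(O)cc1)c1cccnc1`: > 1000 nM
- compound 2 `CCCC1(c2ccc(O)cc2)C(=O)Nc2c1ccc(F)c2F`: > 1000 nM
- compound 3 `O=C1Nc2c(ccc(F)c2F)C1(c1ccc(O)cc1)C1CCCCCCC1`: > 1000 nM

Compound 3 stands at a limit, > 1000 nM, and gives no rank within the series. The next compound, compound 4 `O=C1Nc2c(ccc(F)c2F)C1(CC1CCCCC1)c1ccc(O)cc1`, carries cyclohexylmethyl in place of cyclooctyl on a saturated ring carbon.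

Going by the values given here, three measured steps bear on this change, since all of them alter the same carbon. The closest is a step that the two limits leave unreadable from compound 2 to compound 3, which exchanges one carbon-only group for another. The other two are a step that the two limits leave unreadable from compound 1 to compound 2 and a step that the two limits leave unreadable from compound 1 to compound 3. None has a readable size, so none gives a direction for the new change. The only firm observation is the limit of > 1000 nM in this assay, at which 3 of the 3 values shown sit. Pyridin-3-yl, propyl and cyclooctyl thus show no measurable activity at this carbon, and nothing in the series points to cyclohexylmethyl behaving differently.

In this assay, no step beyond the scatter is expected, and another limit is the likeliest result. The estimated step is a step that the limit leaves unreadable from compound 3 to compound 4, and its direction is only weakly held. For compound 4 the estimate is 1500 nM, with an expected range of 300 nM to 10000 nM.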

Compound 4, half-maximal inhibitory concentration: > 1000 nM
Compound 4: no number, only a limit; the forecaster's own chance of this, stated with the estimate: 75%; the middle value is on the limit's open side.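

Compound 4 gives > 1000 nM in this assay, a limit and not a number. Going by these compounds alone, as a result, no step among compound 1, compound 2, compound 3 and compound 4 can be read. The compounds shown leave open which group on this saturated ring carbon, if any, would give a measurable value, since every result sits at the same limit: the limit of > 1000 nM in this assay, at which 4 of the 4 values shown sit.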